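The source may hold more compounds than are shown below. What is called first, only, known or untested is meant among the compounds shown, and "the series" means these compounds.

Measured so far in an ADME assay on HEK293 cells (Homo sapiens) for cytotoxicity, read by resazurin assay, with a stated time of 72 h; on this read-out lower numbers stand for higher toxicity in this test and higher numbers for lower toxicity in this test:

- compound 1 `O=C(O)c1ccc(COCc2cccc3nc(C(=O)NCc4ccccc4)[nH]c(=O)c23)cc1`: > 20000 nM (a limit)
- compound 2 `CCc1cccc(C(C)NC(=O)c2nc3cccc(COCc4ccc(C(=O)O)cc4)c3c(=O)[nH]2)c1`: > 20000 nM (a limit)

Compound 2 has no numerical value, only the limit > 20000 nM. The whole record is the limit of > 20000 nM in this assay, at which 2 of the 2 values shown sit. For the measured compounds named here, the one measured step, 1-(3-ethylphenyl)ethyl in place of benzyl on an amide-type nitrogen, is a step that the two limits leave unreadable from compound 1 to compound 2. Compound 3 `O=C(O)c1ccc(COCc2cccc3nc(C(=O)NCc4cccc(C(F)(F)F)c4)[nH]c(=O)c23)cc1` differs from compound 2 by 3-(trifluoromethyl)benzyl in place of 1-(3-ethylphenyl)ethyl at that same nitrogen: 3-(trifluoromethyl)benzyl in place of 1-(3-ethylphenyl)ethyl on an amide-type nitrogen. The expectation rests on compound 1, whose benzyl amide also gave only the limit > 20000 nM. No readable step sets a size, so no change beyond the scatter is expected, and a further limit is the likeliest report. The expected step is a step that the limit leaves unreadable from compound 2 to compound 3. Compound 3 is estimated at 25000 nM, within an expected range from 12000 nM to 50000 nM.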

Compound 3, half-maximal cytotoxic concentration: > 20000 nM
Compound 3 gave a limit, no number; the forecaster's own chance of this, stated with the estimate: 85%; the middle value is on the limit's open side.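

The steps to compound 3 from compound 1 and from compound 2 cannot be read, because all three compounds give only a limit: the limit of > 20000 nM in this assay, at which 3 of the 3 values shown sit.

The compounds shown leave open where the true cytotoxic concentration of each lies, and whether any change on the amide-type nitrogen alters it.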